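Taking one chloro off compound 3

This account rests on a few compounds, and the source may have more. Where it says the series, first, only, none or still open, it means among the compounds named here.

In a functional assay on A549 cells (Homo sapiens) for cytotoxicity, read by MTT assay, with a stated time of 72 h (on this read-out lower numbers stand for stronger inhibition and higher numbers for weaker inhibition), compound 1 `CC1CCN(Cc2ccc3nc(NC(=O)N/N=C/c4cn(Cc5ccc(Cl)cc5Cl)c5ccccc45)sc3c2)CC1` gives 3640 nM and compound 2 `CN(C)Cc1ccc2nc(NC(=O)N/N=C/c3cn(Cc4ccc(C(C)(C)C)cc4)c4ccccc34)sc2c1` gives 1850 nM on the same read-out. Compound 3 `CCN(CC)Cc1ccc2nc(NC(=O)N/N=C/c3cn(Cc4ccc(Cl)cc4Cl)c4ccccc34)sc2c1` gives 1900 nM and lies within the scatter of both. Compound 4 `CCN(CC)Cc1ccc2nc(NC(=O)N/N=C/c3cn(Cc4ccc(Cl)cc4)c4ccccc34)sc2c1` is reached from compound 3 by hydrogen in place of chloro on an aromatic carbon and so carries 4-chlorobenzyl where compound 3 carries 2,4-dichlorobenzyl. Only one measured step links two of these compounds at a single place, a 1.9-fold lower number from compound 1 to compound 3 (0.28 log units; within the scatter) and it exchanges the amine while the 2,4-dichlorobenzyl group stays. Going by the values given here, no measured pair shows the loss of this chloro alone. Compound 2 has no chloro on its benzyl group and differs in the amine as well, yet its 1850 nM stays within the scatter of compound 3. No shift beyond the scatter is therefore expected, and the estimated step is a 1.1-fold higher number from compound 3 to compound 4 (0.02 log units; within the scatter) in either direction. For compound 4 the expected value is 2000 nM with an estimated range of 900 nM to 4500 nM in this assay.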

Compound 4, half-maximal inhibitory concentration: 2940 nM
For compound 4 the middle estimate is 1.5-fold (0.17 log units) below the measured one; the range from low to high includes it.
By their numbers in this assay, from the lowest: compounds 2, 3, 4 and 1 (each within the scatter of the next).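

In this assay, going by these compounds alone, the step of a 1.5-fold higher number from compound 3 to compound 4 (0.19 log units; within the scatter) gives the first reading of this chloro on its own, on the aromatic carbon ortho to a large group and meta to a chloro group. With the diethylamino group and the rest of the molecule held fixed, 2,4-dichlorobenzyl and 4-chlorobenzyl cannot be told apart on this read-out, so this chloro is not needed to hold the value within the scatter. Nothing available on these compounds offers an explanation for this result.

The compounds shown leave open how a fluoro or a methoxy group on this carbon would compare with chloro and hydrogen. They also leave open whether the same exchange reads alike when the amine is 4-methylpiperidin-1-yl rather than diethylamino.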